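The source may hold more compounds than are shown below. What is called first, only, known or untested is meant among the compounds shown, and "the series" means these compounds.

In a functional assay on COLO 205 cells (Homo sapiens) for cytotoxicity, read by MTT assay, with a stated time of 48 h (a lower number here means a stronger inhibitor, a higher number a weaker inhibitor), compound 1 `CCOC(=O)C1=C(C)NC(=S)NC1c1cccc(OC/C=C/COc2cccc(C3NC(=S)NC(C)=C3C(=O)OCC)c2)c1` is reported only as a limit of the assay, > 200 ug/mL. Compound 2 `COC(=O)[C@@H]1CCCN1C(=O)C1=C(C)NC(=S)NC1c1cccc(OC/C=C/COc2cccc(C3NC(=S)NC(C)=C3C(=O)N3CCC[C@H]3C(=O)OC)c2)c1` gives 127 ug/mL. Compound 3 `CCOC(=O)C1=C(C)NC(=S)NC1c1ccc(OC/C=C\COc2ccc(C3NC(=S)NC(C)=C3C(=O)OCC)cc2OC)c(OC)c1` gives 120 ug/mL, which lies within the usual scatter of the value for compound 2. Compound 4 `CCOC(=O)C1=C(C)NC(=S)NC1c1ccc(OC/C=C/COc2ccc(C3NC(=S)NC(C)=C3C(=O)OCC)cc2OC)c(OC)c1` departs from compound 3 in its drawn geometry alone: the two compounds have the same atoms and bonds; at least one stereo element is drawn with a configuration in one of them and without one in the other: 1 of 3 stereo elements differ; a double bond is drawn Z in compound 3 and E in compound 4. The two compounds have the same atoms and bonds, and a double bond is drawn Z in compound 3 and E in compound 4. Going by the values given here, no measured pair here shows the effect of such a change, so no step beyond the scatter is expected in this assay. Compound 4 is estimated at 125 ug/mL, with an expected range of 70 ug/mL to 200 ug/mL.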

Compound 4, half-maximal inhibitory concentration: 90 ug/mL
Compound 4: the middle estimate sits 1.4-fold (0.14 log units) above what was measured; low and high end bracket the measured number.
By their numbers in this assay, from the lowest: compounds 4, 3 and 2 (each within the scatter of the next). At a limit, above all of these: compound 1.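

Going by these compounds alone, this is the first pair here that differs in one place only, so the double bond of the linking chain can be judged on its own. In this assay, turning that double bond from Z to E gives a 1.3-fold lower number from compound 3 to compound 4 (0.12 log units; within the scatter), so the two drawn geometries cannot be told apart in this assay. One caution applies to this reading: the fact that one of compounds 3 and 4 is drawn with a defined configuration and the other without, at the place where they differ

From the compounds shown here alone, it remains open whether a longer chain in place of the one holding this double bond, or a carboxylic acid in place of the ethyl ester, would move the number beyond the scatter.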